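A few compounds are considered here, and "the series" means these few. Any claim that something is new, unique, unknown or untested is made for them only; others in the source may bear on it.

Compound 1 `CCCCc1nc(C)c(CC(=O)N(C)C)c(=O)n1Cc1ccc(-c2ccccc2-c2nnn[nH]2)cc1` gives 0.018 mg/kg
Compound 2 `CCCCc1nc(C)c(CCC(=O)N2CCCCC2)c(=O)n1Cc1ccc(-c2ccccc2-c2nnn[nH]2)cc1` gives 0.164 mg/kg

In an in vivo functional assay on the whole organism for inhibition, with Rattus norvegicus as the target (on this read-out higher numbers stand for an effect only at larger amounts of compound and lower numbers for an effect already at smaller amounts), compound 2 has the higher of the two numbers, so it needs the larger dose for the same effect. Compound 3 `CCCCc1nc(C)c(CCC(=O)N2CC(C)OC(C)C2)c(=O)n1Cc1ccc(-c2ccccc2-c2nnn[nH]2)cc1` carries 2,6-dimethylmorpholin-4-yl in place of piperidin-1-yl on a carbonyl carbon, and the ring stays six-membered and non-aromatic: 2,6-dimethylmorpholin-4-yl in place of piperidin-1-yl on a carbonyl carbon is the full count. Within the data shown here, only one measured step is available, a 9.1-fold higher number from compound 1 to compound 2 (0.96 log units; beyond the scatter), and it is a loose guide. It also alters the group on the carbonyl carbon, but it replaces dimethylcarbamoyl with ((piperidin-1-yl)carbonyl)methyl, which is a different change. Among the measured compounds shown here, no measurement yet isolates a ring exchange like this one, so no clear direction can be argued. The expected size is a 1.2-fold higher number from compound 2 to compound 3 (0.09 log units; within the scatter). A move as large as the step from compound 1 to compound 2 is not anticipated. Compound 3 is estimated at 0.2 mg/kg with 0.05 mg/kg and 0.7 mg/kg as the expected ends of its range.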

Compound 3, dose for half-maximal effect: 0.228 mg/kg
Estimate against measurement, compound 3: 1.1-fold (0.06 log units) below; the measured number falls inside the stated range.
By their numbers in this assay, from the lowest: compound 1; then compounds 2 and 3 (each within the scatter of the next).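

In this assay, the exchange of piperidin-1-yl for 2,6-dimethylmorpholin-4-yl on a carbonyl carbon gives a 1.4-fold higher number from compound 2 to compound 3 (0.14 log units; within the scatter), so a larger ring group carrying a hydrogen-bond acceptor leaves the dose out of reach of any distinction here. The gap to the dimethylcarbamoyl compound remains clear, at a 13-fold higher number from compound 1 to compound 3 (1.10 log units; beyond the scatter), so it persists with either of these two rings on the carbonyl carbon. No supporting data bear on the reason for either result.

From the compounds shown here alone, both steps from compound 1 swap the amide group and add a chain carbon together, so the share of each remains open. A 2-(dimethylcarbamoyl)ethyl group, or a (piperidin-1-yl)carbonyl group on the shorter chain, would separate the two changes, and an unsubstituted morpholin-4-yl ring would test the ring oxygen without the two methyl groups.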